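The source may hold more compounds than are shown below. What is called first, only, known or untested is meant among the compounds shown, and "the series" means these compounds.

In an ADME assay on HEK-293T cells (Homo sapiens) for inhibition, read by CCK-8 assay, with a stated time of 48 h, tested at 20 uM (a higher number here means more inhibition of growth at the concentration tested, a lower number less inhibition of growth), compound 3 (`COc1ccc(S(=O)(=O)Oc2ccccc2/C=C(\C#N)C(=O)Nc2nnc(Cc3ccccc3)s2)cc1`) gives 23% on a read-out shared with two close relatives. Compound 1 (`COc1ccc(S(=O)(=O)Oc2ccccc2/C=C(\C#N)C(=O)Nc2nnc(Cc3cccc4ccccc34)s2)cc1`) gives 29% and compound 2 (`N#C/C(=C\c1ccccc1OS(=O)(=O)c1ccc(F)cc1)C(=O)Nc1nnc(Cc2cccc3ccccc23)s1`) gives 15% in the same test. Compound 3 stands within the usual scatter of each of them, so no order can be claimed for it against either one.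

Compound 4 (`N#C/C(=C\c1ccccc1OS(=O)(=O)c1ccc(F)cc1)C(=O)Nc1nnc(Cc2ccccc2)s1`) has not yet been measured. It differs from compound 3 by a single change (fluoro in place of methoxy on an aromatic carbon), with fluoro in place of methoxy on an aromatic carbon, para to a large group, so that 4-methoxyphenyl becomes 4-fluorophenyl.

The same swap has been measured once, on the naphthalen-1-yl series, where it gave a number 14 percentage points lower from compound 1 to compound 2 (beyond the scatter) and so offers the closest guide. The other measured step, phenyl in place of naphthalen-1-yl, gave a number 6 percentage points lower from compound 1 to compound 3 (within the scatter) and leaves the swapped group untouched, so it adds little here. A single pair is thin evidence, and the swap may not carry over in full to a compound with phenyl in that place.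

Taking this into account, a number 12 percentage points lower from compound 3 to compound 4 (beyond the scatter) is the step expected in this assay and it points to a lower number of modest size. Compound 4 is expected at 11% (estimated range 3% to 21%).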

Compound 4, percent growth inhibition at one concentration: 6%
Beside the measured number, compound 4's estimate is 5 percentage points above it; the measured number falls inside the stated range.
By their numbers in this assay, from the lowest: compounds 4, 2, 3 and 1 (each within the scatter of the next, the first and the last beyond it).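

In this assay, the swap from 4-methoxyphenyl to 4-fluorophenyl now has a second reading, a number 17 percentage points lower from compound 3 to compound 4 (beyond the scatter), so the fall seen with naphthalen-1-yl also appears with phenyl, and its size holds steady across the two cores: the same change on two cores in this assay, a number 14 percentage points lower (beyond the scatter) from compound 1 to compound 2 and a number 17 percentage points lower (beyond the scatter) from compound 3 to compound 4, 3 percentage points apart, within the scatter of two such steps. The other change, phenyl in place of naphthalen-1-yl, can now also be read with the fluoro group in place, where it gives a number 9 percentage points lower from compound 2 to compound 4 (within the scatter), and it stays within the scatter with either group: the same change on two cores in this assay, a number 6 percentage points lower (within the scatter) from compound 1 to compound 3 and a number 9 percentage points lower (within the scatter) from compound 2 to compound 4, 3 percentage points apart, within the scatter of two such steps. Across these four compounds, the change from methoxy to fluoro is therefore the one that moves the number beyond the scatter, while the change from naphthalen-1-yl to phenyl does not.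

The compounds shown carry only methoxy or fluoro at this place, so it remains open how a chloro, a methyl or an amino group there would read, and whether the number follows any trend across such groups. Each reading also comes from a single concentration on one cell line, which leaves open how these compounds would compare at other concentrations.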